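The source may hold more compounds than are shown below. What is called first, only, known or untested is meant among the compounds shown, and "the series" means these compounds.

Compound 2 `CSc1ccc(Cc2nn(C(C)(C)C)c(=O)c3ccccc23)cc1` stands at the edge of what a functional assay on aorta with Alpha-1D adrenergic receptor (Rattus norvegicus) as the target (a lower number here means that less compound is needed, a higher number that more compound is needed for the effect), can report: in this assay compound 2 gives > 100000 nM, which is a limit rather than a number. Compound 3 `CC(C)(C)n1nc(Cc2ccc(Cl)cc2)c2ccccc2c1=O` also reaches only a limit, giving > 100000 nM in this assay. Compound 1 `Cn1nc(Cc2cccc3ccccc23)c2ccccc2c1=O` gives 14000 nM in this assay. The step from compound 2 to compound 3, a step that the two limits leave unreadable from compound 2 to compound 3, cannot be sized because the limit of > 100000 nM in this assay, at which 2 of the 3 values shown sit, holds both of its ends. Compound 4 `CCCCn1nc(Cc2ccc(SC)cc2)c2ccccc2c1=O` differs from compound 2 by butyl in place of tert-butyl on an aromatic nitrogen. Going by the values given here, no measured step covers this change on an aromatic nitrogen, so no shift beyond the scatter is expected, and the chance that compound 4 again returns only a limit stays high. Compound 4 is estimated at 70000 nM, within 15000 nM to 300000 nM, an expected step of an at least 1.4-fold lower number from compound 2 to compound 4 (0.15 log units; that floor lies within the scatter).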

Compound 4, half-maximal effective concentration: > 100000 nM
Compound 4: a limit, no number (the forecaster's own chance of this, stated with the estimate: 65%); middle value at least 1.4-fold (0.15 log units) from the limit.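

Compound 2 and compound 4 both reach only a limit, so no step between them can be read: the limit of > 100000 nM in this assay, at which 3 of the 4 values shown sit.

The compounds shown leave open how butyl and tert-butyl on the aromatic nitrogen compare in this assay.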